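Acetylation of a Hydroxy Group and HeLa Cell Cytotoxicity

The compounds below may be only part of what the source reports. "The series", "measured", "known", "first", "only" and "open" are said of these compounds alone.

Compound 1 `C=C1C(=O)O[C@]2(C)CC[C@@H]1C[C@H](O)[C@@]1(C)CC[C@H](O1)C(=C)CC[C@H]2OC(C)=O` carries a free hydroxy group on its core. In a functional assay on HeLa cells (Homo sapiens) for cytotoxicity, read by MTT assay (a lower number here means that less compound is needed, a higher number that more compound is needed for the effect), compound 1 gives only a limit of < 20 ug/mL. Compound 2 `C=C1C(=O)O[C@]2(C)CC[C@@H]1C[C@H](OC(C)=O)[C@@]1(C)CC[C@H](O1)C(=C)CC[C@H]2OC(C)=O` differs from compound 1 by acetyl in place of hydrogen on an oxygen on a saturated carbon. In this assay compound 2 likewise reaches only the limit of < 20 ug/mL. The step that the two limits leave unreadable from compound 1 to compound 2 therefore cannot be read. Compound 3 `C=C1C(=O)O[C@]2(C)CC[C@@H]1C[C@H](O)[C@@]1(C)CC[C@H](O1)[C@](C)(O)CCC2=O` rests on a different core; the difference between the two cores is not broken down here. In this assay compound 3 too gives only a limit of < 20 ug/mL. Compound 4 `C=C1C(=O)O[C@]2(C)CC[C@@H]1C[C@H](OC(C)=O)[C@@]1(C)CC[C@H](O1)[C@](C)(O)CCC2=O` differs from compound 3 by acetyl in place of hydrogen on an oxygen on a saturated carbon, the same change as from compound 1 to compound 2, at the same kind of place. The expected step is a step that the limit leaves unreadable from compound 3 to compound 4, resting on (the limit of < 20 ug/mL in this assay, at which 3 of the 3 values shown sit). Compound 4 is expected to give about 8 ug/mL.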

Compound 4, concentration for half-maximal effect: < 20 ug/mL
Compound 4: a limit, no number; the forecaster's own chance of this, stated with the estimate: 70%; the middle value lies beyond the limit too.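

In this assay, going by these compounds alone, compound 4 gives only a limit, < 20 ug/mL, so the step from compound 3 to compound 4 cannot be read, any more than the one from compound 1 to compound 2. The compounds shown leave open what hydroxy to acetoxy does to the actual values on either core, as all of them rest on one limit: the limit of < 20 ug/mL in this assay, at which 4 of the 4 values shown sit.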